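This account rests on a few compounds, and the source may have more. Where it says the series, first, only, none or still open, it means among the compounds named here.

Measured in a functional assay on MV4-11 cells (Homo sapiens) for antiproliferative activity, read by resazurin assay, with a stated time of 72 h; on this read-out higher numbers stand for weaker inhibition and lower numbers for stronger inhibition:

- compound 1 `C(=C/c1nn2c(-c3ccncc3)nnc2s1)\c1ccco1`: 66500 nM
- compound 2 `COc1ccccc1-c1nnc2sc(/C=C/c3ccco3)nn12`: 1070 nM
- compound 3 `C(=C/c1nn2c(-c3ccccc3)nnc2s1)\c1ccco1`: 64700 nM

With 64700 nM, compound 3 cannot be told apart from compound 1, as a 1.0-fold lower number from compound 1 to compound 3 (0.01 log units; within the scatter) shows. Compound 2 stands well clear of this pair, and a 60-fold higher number from compound 2 to compound 3 (1.78 log units; beyond the scatter) places compound 3 on the weak side of the three.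

The next compound, compound 4 `CN(C)c1ccc(-c2nnc3sc(/C=C/c4ccco4)nn23)cc1`, carries dimethylamino in place of hydrogen on an aromatic carbon of compound 3, para to a large group (dimethylamino in place of hydrogen on an aromatic carbon). Going by the values given here, two measured steps bear on this change. The swap of pyridin-4-yl for phenyl, a 1.0-fold lower number from compound 1 to compound 3 (0.01 log units; within the scatter), moved nothing measurable, so it offers little guidance. The more useful one is a 60-fold higher number from compound 2 to compound 3 (1.78 log units; beyond the scatter), which shows that a single group on this ring can matter greatly in this assay. However, that group is methoxy, it is not dimethylamino, and it does not sit para to a large group, so only part of that step is carried over. A clear drop in the number is therefore expected, though a smaller one than that seen with compound 2.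

The expected move is an 11-fold lower number from compound 3 to compound 4 (1.03 log units; beyond the scatter), and this is only an estimate. For compound 4 the estimated value is 6000 nM, with an expected range from 1000 nM to 40000 nM.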

Compound 4, half-maximal inhibitory concentration: 51500 nM
Compound 4: middle estimate off by 8.6-fold (0.93 log units), on the low side; measured number outside the range, above it.
By their numbers in this assay, from the lowest: compound 2; then compounds 4, 3 and 1 (each within the scatter of the next).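

In this assay, placing dimethylamino on the aromatic ring of compound 3, para to a large group, gives a 1.3-fold lower number from compound 3 to compound 4 (0.10 log units; within the scatter) and so a number that cannot be told apart from that of compound 3. The earlier step, a 60-fold higher number from compound 2 to compound 3 (1.78 log units; beyond the scatter), showed that one group on this ring can matter greatly, and compound 4 now shows that this does not hold for every group added to the ring: dimethylamino, at this place, brings no measurable gain over hydrogen. Of the compounds shown, only compound 2 stands apart, with 1070 nM as its value, while compounds 1, 3 and 4 sit together on the weak side. No measurement here explains why dimethylamino and methoxy differ in this way.

The compounds shown leave open whether methoxy itself, placed para to a large group, would give a number like that of compound 2. They also leave open whether a smaller primary amine or a carboxylic acid at that same place would move the number at all.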